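The compounds below may be only part of what the source reports. "The series", "measured", "known", "first", "only" and "open" are said of these compounds alone.

Working notes on a small thiophene-fused series tested in a functional assay on HeLa cells (Homo sapiens) for cytotoxicity, read by cell counting, with a stated time of 72 h; on this read-out higher numbers stand for weaker inhibition and lower numbers for stronger inhibition.

Compound 1 `Nc1nc(Cl)nc2ccsc12` carries an amino group and a chloro group on the shared core. In this assay compound 1 reaches only the limit > 250000 nM. Compound 2 `Clc1nc(-n2cncn2)c2sccc2n1` differs from compound 1 by 1H-1,2,4-triazol-1-yl in place of amino on an aromatic carbon. In this assay compound 2 likewise reaches only the limit > 250000 nM. The step that the two limits leave unreadable from compound 1 to compound 2 is therefore not readable in size; the two values sit at the limit of > 250000 nM in this assay, at which 2 of the 3 values shown sit.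

Compound 3 `Nc1nc(Cl)nc2c(Br)csc12` differs from compound 1 by bromo in place of hydrogen on an aromatic carbon. In this assay, going by the values given here, compound 3 gives 96000 nM, the only actual number in the set, the step being an at least 2.6-fold lower number from compound 1 to compound 3 (0.41 log units; beyond the scatter).

Compound 4 `Clc1nc(-n2cncn2)c2scc(Br)c2n1` is not yet measured. It differs from compound 3 by 1H-1,2,4-triazol-1-yl in place of amino on an aromatic carbon. This is the same change as made from compound 1 to compound 2, where the size of the step remained hidden by the two limits. Among the compounds with values here, for compound 4 a step of a 1.7-fold higher number from compound 3 to compound 4 (0.22 log units; within the scatter) is expected, resting on the single readable number of compound 3, 96000 nM. It is also possible that the assay again reports only a limit for compound 4. Compound 4 is thus estimated at 160000 nM, within 45000 nM to 400000 nM.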

Compound 4, half-maximal inhibitory concentration: 116000 nM
For compound 4 the middle estimate is 1.4-fold (0.14 log units) above the measured one, within the range that was stated.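

In this assay, 1H-1,2,4-triazol-1-yl in place of amino on the bromo-bearing core gives a 1.2-fold higher number from compound 3 to compound 4 (0.08 log units; within the scatter), so the two groups cannot be told apart on that core. Bromo in place of hydrogen gives an at least 2.1-fold lower number from compound 2 to compound 4 (0.33 log units; beyond the scatter), and this change now points the same way on two cores: the same change on two cores in this assay, an at least 2.6-fold lower number (0.41 log units; beyond the scatter) from compound 1 to compound 3 and an at least 2.1-fold lower number (0.33 log units; beyond the scatter) from compound 2 to compound 4; the limit leaves it open whether they differ. The step from compound 1 to compound 2 cannot be read, so the series does not show whether the result for the 1H-1,2,4-triazol-1-yl change on the bromo-bearing core carries over to the core without bromo, and the size of the bromo step on either core also stays unsettled.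

Going by these compounds, it remains open whether a methyl group or iodo in the place of bromo would give a similar step. On these data alone, it is equally open whether a dimethylamino group or morpholine in the place of amino or 1H-1,2,4-triazol-1-yl would also stay within the scatter of compound 3 and compound 4.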